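Moving the hydroxyurea along the chain in a 5-lipoxygenase series

This account rests on a few compounds, and the source may have more. Where it says the series, first, only, none or still open, it means among the compounds named here.

Compound 1 `NC(=O)N(O)CCC#C[C@@H]1CC[C@@H](CN2CCN([C@H](c3ccccc3)c3ccc(Cl)cc3)CC2)O1`: 310 nM
Compound 2 `CC(C#Cc1ccc(CN2CCN([C@H](c3ccccc3)c3ccc(Cl)cc3)CC2)o1)N(O)C(N)=O`: 3500 nM
Compound 3 `NC(=O)N(O)CCC#C[C@@H]1CC[C@@H](COc2ccc(F)cc2)O1`: 117 nM

In an assay on blood for inhibition of Polyunsaturated fatty acid 5-lipoxygenase (Homo sapiens) (a higher number here means a weaker inhibitor, a lower number a stronger inhibitor), compound 2 gives the highest number of the three, beyond the scatter from compound 1 and further still from compound 3. Compound 4 `NC(=O)N(O)CCC#Cc1ccc(CN2CCN([C@H](c3ccccc3)c3ccc(Cl)cc3)CC2)o1` has not been measured. It differs from compound 2 by 2-(carbamoyl(hydroxy)amino)ethyl in place of 1-(carbamoyl(hydroxy)amino)ethyl on a triple-bonded carbon. Compounds 1 and 3 both carry the 2-(carbamoyl(hydroxy)amino)ethyl arrangement, and both give lower numbers in this assay than compound 2, so a step downward is expected, beyond the scatter, though the rest of the structure matches compound 1 rather than compound 3. The expected step is a 5.8-fold lower number from compound 2 to compound 4 (0.77 log units; beyond the scatter). Compound 4 is estimated at 600 nM, with a range from 200 nM to 2000 nM.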

Compound 4, half-maximal inhibitory concentration: 420 nM
Compound 4: middle estimate off by 1.4-fold (0.15 log units), on the high side; the measured number falls inside the stated range.
By their numbers in this assay, from the lowest: compound 3; then compounds 1 and 4 (each within the scatter of the next); then compound 2.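

In this assay, the change from 1-(carbamoyl(hydroxy)amino)ethyl to 2-(carbamoyl(hydroxy)amino)ethyl on a triple-bonded carbon gives an 8.3-fold lower number from compound 2 to compound 4 (0.92 log units; beyond the scatter). Among the compounds shown here, this is the first pair here that differs in one place, so the effect of this arrangement can now be read directly, with the rest of the structure and the atoms unchanged. Nothing measured accounts for the step. The compounds shown leave open whether a longer chain carrying the carbamoyl(hydroxy)amino group would give a still lower number, and whether a carboxylic acid could stand in for that group.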